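Chain extension at the hydroxamate in the para series

The source may hold more compounds than are shown below. What is called first, only, known or untested is meant among the compounds shown, and "the series" means these compounds.

Compound 3 `C#CCN(C)Cc1ccc(NC(=O)CCC(=O)NO)cc1` is the short-chain para-substituted member of the series. In a functional assay on DU-145 cells (Homo sapiens) for inhibition, read by MTT assay, with a stated time of 48 h (a lower number here means a stronger inhibitor of growth, a higher number a weaker inhibitor of growth), compound 3 gives > 10000 nM, which is a limit of the assay rather than a number. Compound 4 `C#CCN(C)Cc1ccc(NC(=O)CCCCCC(=O)NO)cc1` is its chain-extended relative: 3-(hydroxycarbamoyl)propyl in place of hydroxycarbamoyl on a saturated chain carbon, two bonds along the chain from a carbonyl carbon. Among the measured compounds shown here, the only measured step of related kind is the shorter extension among the meta compounds, compound 1 `C#CCN(C)Cc1cccc(NC(=O)CCCC(=O)NO)c1` and compound 2 `C#CCN(C)Cc1cccc(NC(=O)CCCCC(=O)NO)c1`. In this assay compound 1 gives > 10000 nM, a limit of the assay. In this assay compound 2 gives 9750 nM. That step, an at least 1.0-fold lower number from compound 1 to compound 2 (0.01 log units; that floor lies within the scatter), starts from the limit and so sets only a floor; the limit of > 10000 nM in this assay, at which 2 of the 3 values shown sit, caps what these pairs can show. A larger lowering is expected here, an at least 3.3-fold lower number from compound 3 to compound 4 (0.52 log units; beyond the scatter). Compound 4 is estimated at 3000 nM, within 600 nM to 10000 nM.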

Compound 4, concentration for 50% growth inhibition: > 10000 nM
Compound 4 gave a limit, no number; the forecaster's own chance of this, stated with the estimate: 30%; middle value at least 3.3-fold (0.52 log units) from the limit.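

Compound 3 and compound 4 both stand as limits, so no step between them can be read: the limit of > 10000 nM in this assay, at which 3 of the 4 values shown sit.

The compounds shown leave open whether 3-(hydroxycarbamoyl)propyl in place of hydroxycarbamoyl changes the number at all in this assay.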